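Plasma protein binding in the thienopyridazine amide series

The source may report more compounds than this note shows. Statements on the series, on what has been measured and on what is new or still open speak of the compounds shown alone.

Of the compounds shown here, two of the shared core have been measured in an ADME assay on a cell-free system (plasma, Rattus norvegicus) for protein binding; a lower number here means a smaller unbound share, a higher number a larger unbound share of the compound. Compound 1 `Cc1c(CF)nnc2sc(C(=O)NC3CN(c4ncc(C(F)(F)F)cn4)C3)c(N)c12` gives 0.034 in this assay. Compound 2 `COc1cc(N2CC(NC(=O)c3sc4nnc(Cl)c(C)c4c3N)C2)c(Cl)cn1` gives 0.005 in this assay. Compound 1 therefore holds the higher of the two numbers, and its gap to compound 2 lies beyond the scatter. Compound 2 differs from compound 1 in several places at once, so no single step can be read from that pair.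

Compound 3 `COc1nnc2sc(C(=O)NC3CN(c4ncc(C(F)(F)F)cn4)C3)c(N)c2c1C` has not yet been measured in this assay. It differs from compound 1 in one place: methoxy in place of fluoromethyl on an aromatic carbon. Going by the values given here, no measured pair isolates this change, so the expectation rests on compound 1 alone. The step from compound 1 to compound 3 is expected to be small, without a clear direction, and not beyond the scatter. Compound 3 is expected to give 0.04 in this assay, within 0.02 to 0.08. The expected step of a 1.2-fold higher number from compound 1 to compound 3 (0.07 log units; within the scatter) stays inside the usual scatter.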

Compound 3, unbound fraction: 0.018
Compound 3: middle estimate off by 2.2-fold (0.35 log units), on the high side; the measured number lies below the stated range.
By their numbers in this assay, from the lowest: compound 2; then compounds 3 and 1 (each within the scatter of the next).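

Going by these compounds alone, the step of a 1.9-fold lower number from compound 1 to compound 3 (0.28 log units; within the scatter) in this assay is the first reading of a change at a single place, since the earlier pair differs in several places at once. At this position, on an aromatic carbon next to the ring nitrogen and ortho to a methyl group, methoxy in place of fluoromethyl brings one more hydrogen-bond acceptor, yet the step stays within the scatter. No accompanying measurement bears on this step, so it stands as an observation alone.

Still open, on these data alone, is whether a larger change at this position, such as an amine or a longer alkoxy chain, would move the unbound share beyond the scatter. As far as these compounds go, it is equally open whether the same swap would give a similar step with a different group on the azetidine nitrogen.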